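Cytotoxicity notes: truncation of the urea side chain

This account rests on a few compounds, and the source may have more. Where it says the series, first, only, none or still open, it means among the compounds named here.

Compound 2 `CCOC(=O)CNC(=O)NC1=CS(=O)(=O)O[C@@]12[C@@H](CO[Si](C)(C)C(C)(C)C)O[C@@H](n1cc(C)c(=O)n(C)c1=O)[C@@H]2O[Si](C)(C)C(C)(C)C` and compound 1 `C=C(C)C(=O)NC(=O)NC1=CS(=O)(=O)O[C@@]12[C@@H](CO[Si](C)(C)C(C)(C)C)O[C@@H](n1cc(C)c(=O)n(C)c1=O)[C@@H]2O[Si](C)(C)C(C)(C)C` share the same core and differ only in the group on the amide-type nitrogen. In a functional assay on HEL cells (Homo sapiens) for cytotoxicity, read by microscopy (a higher number here means that more compound is tolerated, a lower number that less compound is tolerated), compound 1 gives 20000 nM, and compound 2 gives 16000 nM. Within the data shown here, the single measured step, a 1.3-fold lower number from compound 1 to compound 2 (0.10 log units; within the scatter), is within the scatter, so the two compounds stand together on this read-out and neither can be set apart from the other.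

Compound 3 `Cc1cn([C@@H]2O[C@H](CO[Si](C)(C)C(C)(C)C)[C@@]3(OS(=O)(=O)C=C3NCC(=O)C(=O)O)[C@H]2O[Si](C)(C)C(C)(C)C)c(=O)n(C)c1=O` is not yet measured. It differs from compound 2 as follows: (carboxycarbonyl)methyl in place of ((ethoxycarbonyl)methyl)carbamoyl on an amine nitrogen. Among the measured compounds shown here, no measured step touches this kind of change; the only comparison available, compound 1 against compound 2, exchanges one acyl group for another on the amide-type nitrogen and moves the number by no more than the scatter. There is therefore no basis in these data for predicting a shift in either direction, and a step of no more than the scatter is expected, no change at the digits printed from compound 2 to compound 3 (within the scatter). Compound 3 is estimated at 16000 nM in this assay, with a range from 5000 nM to 50000 nM.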

Compound 3, minimum cytotoxic concentration: 400000 nM
For compound 3 the middle estimate is 25-fold (1.40 log units) below the measured one; measured number outside the range, above it.
By their numbers in this assay, from the lowest: compounds 2 and 1 (each within the scatter of the next); then compound 3.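

In this assay, this amine nitrogen proves sensitive to its substituent: with (carboxycarbonyl)methyl in place of the carbamoyl side chains, there is a 25-fold higher number from compound 2 to compound 3 (1.40 log units; beyond the scatter) and a 20-fold higher number from compound 1 to compound 3 (1.30 log units; beyond the scatter), so more compound is tolerated. The earlier comparison gave no sign of this, since changing the group further out on the amide-type nitrogen gave only a 1.3-fold lower number from compound 1 to compound 2 (0.10 log units; within the scatter), which left compounds 1 and 2 together within the scatter. Both large steps end at compound 3, and the scatter-level gap between their starting points means that the two carbamoyl side chains, though different, stand on the same side of this change.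

The change removes the carbamoyl unit and introduces the carboxycarbonyl end in a single move, so the compounds shown do not separate the two contributions, and nothing available bears on why the number rises. A carbamoyl chain ending in a free carboxylic acid, set against a plain ethyl group on the amine nitrogen, would show which part of the change goes with the step.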